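Neopentyl for 1-methylbutyl at the limit of tolerance

The source may hold more compounds than are shown below. What is called first, only, known or untested is meant among the compounds shown, and "the series" means these compounds.

compound 1 `CNc1cc(Oc2c(OC)cc3cc(C#N)ccc3c2OC)nc(Nc2ccc(C#N)cc2)n1`: 239000 nM
compound 2 `CCNc1cc(Oc2c(OC)cc3cc(C#N)ccc3c2OC)nc(Nc2ccc(C#N)cc2)n1`: > 125000 nM
compound 3 `CCCC(C)Nc1cc(Oc2c(OC)cc3cc(C#N)ccc3c2OC)nc(Nc2ccc(C#N)cc2)n1`: > 125000 nM

These three compounds share one core and were all tested in an ADME assay on MT4 cells (Homo sapiens) for cytotoxicity, read by MTT assay, with a stated time of 5 days; a higher number here means that more compound is tolerated, a lower number that less compound is tolerated. Among the measured compounds shown here, compound 1 gives 239000 nM, the only actual number among them. Compound 2 gives > 125000 nM, which is a limit. Compound 3 gives > 125000 nM, which is also a limit and not a number. Compound 3 therefore stands at the limit of > 125000 nM in this assay, at which 2 of the 3 values shown sit.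

The next compound is compound 4 `COc1cc2cc(C#N)ccc2c(OC)c1Oc1cc(NCC(C)(C)C)nc(Nc2ccc(C#N)cc2)n1`. The change is neopentyl in place of 1-methylbutyl on a nitrogen on an aromatic ring.

For the measured compounds named here, three measured steps bear on this change: a step that the limit leaves unreadable from compound 1 to compound 2, a step that the limit leaves unreadable from compound 1 to compound 3 and a step that the two limits leave unreadable from compound 2 to compound 3. None of them has a readable size, so none points in a direction. Going by the values given here, the one actual number, compound 1 at 239000 nM, serves as the anchor for the expectation. No shift beyond the usual scatter is expected in this assay, in either direction, and the report may again be only a limit. The estimated change is a step that the limit leaves unreadable from compound 3 to compound 4. For compound 4 the expected value is 150000 nM, with an estimated range from 70000 nM to 320000 nM.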

Compound 4, half-maximal cytotoxic concentration: > 125000 nM
Compound 4: only a limit was reported; the forecaster's own chance of this, stated with the estimate: 60%; the middle value does not contradict the limit.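

In this assay compound 4 gives > 125000 nM, which is a limit and not a number, so its steps from compound 1, compound 2 and compound 3 cannot be read. Compound 4 joins the values at the same limit: the limit of > 125000 nM in this assay, at which 3 of the 4 values shown sit. The compounds shown leave open how far compound 2, compound 3 and compound 4 actually differ from one another or from compound 1.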